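Adding 4-bromophenyl to the side chain of compound 3

The compounds below may be only part of what the source reports. "The series", "measured", "known", "first", "only" and "open" are said of these compounds alone.

In a functional assay on DU-145 cells (Homo sapiens) for cytotoxicity, read by trypan blue exclusion, with a stated time of 96 h (on this read-out higher numbers stand for weaker inhibition and lower numbers for stronger inhibition), compound 1 (`COc1ccc(NS(=O)(=O)/C=C/c2c(OC)cc(OC)cc2OC)cc1`) gives 200 nM while compound 2 (`COC(=O)C(C)Nc1cc(NS(=O)(=O)/C=C/c2c(OC)cc(OC)cc2OC)ccc1OC`) gives 100 nM (a pair showing a 2.0-fold lower number from compound 1 to compound 2 (0.30 log units; within the scatter)). Compound 3 (`COc1cc(OC)c(/C=C/S(=O)(=O)Nc2ccc(OC)c(NCC(=O)O)c2)c(OC)c1`) gives 400 nM (its neighbours show a 2.0-fold higher number from compound 1 to compound 3 (0.30 log units; within the scatter) and a 4.0-fold higher number from compound 2 to compound 3 (0.60 log units; beyond the scatter)).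

Compound 4 (`COc1cc(OC)c(/C=C/S(=O)(=O)Nc2ccc(OC)c(NC(C(=O)O)c3ccc(Br)cc3)c2)c(OC)c1`) arises from compound 3 by one change (4-bromophenyl in place of hydrogen on a saturated chain carbon bound to a carbonyl carbon and a nitrogen on an aromatic ring): 4-bromophenyl in place of hydrogen on a saturated chain carbon bound to a carbonyl carbon and a nitrogen on an aromatic ring. For the measured compounds named here, no measured step adds a ring at this carbon. Going by the values given here, the nearest guide is compound 2, the only measured compound branched there, and its step to compound 3 (again a 4.0-fold higher number from compound 2 to compound 3 (0.60 log units; beyond the scatter)) also swaps the methoxycarbonyl for a free acid, so the two changes cannot be separated. A step beyond the scatter is therefore not expected, only a slight lean towards a lower number. In this assay the estimated step is a 1.6-fold lower number from compound 3 to compound 4 (0.20 log units; within the scatter) for this change. For compound 4 the expected value is 250 nM (estimated range 70 nM to 900 nM).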

Compound 4, half-maximal inhibitory concentration: 250 nM
Estimate against measurement, compound 4: no gap at the digits printed, and the stated range covers the measured number.
By their numbers in this assay, from the lowest: compounds 2, 1, 4 and 3 (each within the scatter of the next, the first and the last beyond it).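

In this assay, a whole 4-bromophenyl ring can sit on this saturated chain carbon without moving the number beyond the scatter, with a 1.6-fold lower number from compound 3 to compound 4 (0.20 log units; within the scatter). The full side chain also stays within the scatter of the compound lacking it, with a 1.3-fold higher number from compound 1 to compound 4 (0.10 log units; within the scatter). For the compounds shown here, the only new step beyond the scatter is a 2.5-fold higher number from compound 2 to compound 4 (0.40 log units; beyond the scatter), but it changes the methyl to the ring and the methoxycarbonyl to a free acid at once, so neither change can be held responsible alone.

Nothing available here explains these numbers. As far as these compounds go, it remains open whether the ring or its bromine matters more, and what a plain phenyl, a 4-methoxyphenyl or a methoxycarbonyl in place of the free acid on compound 4 would give.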